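Cyclopropylmethyl in place of isopropyl on the shared core

This account rests on a few compounds, and the source may have more. Where it says the series, first, only, none or still open, it means among the compounds named here.

The series rests on three measured compounds. Compound 1 `CC(=O)N1CCC(C(=O)NCCCNc2nc(Nc3cccc(F)c3)ncc2Br)CC1` gives 430 nM in an assay on isolated protein for inhibition of serine/threonine-protein kinase TBK1 (Homo sapiens); on this read-out lower numbers stand for stronger inhibition and higher numbers for weaker inhibition. Compound 2 `O=C(NCCCNc1nc(Nc2cccc(F)c2)ncc1C1CC1)C1CCC1` gives 8 nM in this assay. Compound 3 `CC(C)c1cnc(Nc2cccc(F)c2)nc1NCCCNC(=O)C1CCC1` carries an isopropyl group where compound 2 carries cyclopropyl. In this assay compound 3 sits at the limit, > 1000 nM, so only a limit and no number is known for it. The move from cyclopropyl to isopropyl brought an at least 120-fold higher number from compound 2 to compound 3 (2.09 log units; beyond the scatter), and compound 3 is one of those at the limit of > 1000 nM in this assay, at which 1 of the 3 values shown sits.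

Compound 4 `O=C(NCCCNc1nc(Nc2cccc(F)c2)ncc1CC1CC1)C1CCC1` differs from compound 3 in one place: cyclopropylmethyl in place of isopropyl on an aromatic carbon. Going by the values given here, the only measured step that bears on this position is the one from compound 2 to compound 3, which was large. A cyclopropyl ring on this carbon, as in compound 2, gave 8 nM. Its isopropyl counterpart, compound 3, reached only the limit. Cyclopropylmethyl restores a three-membered ring but adds a fourth carbon, so the outcome is uncertain and a wide range is appropriate. Compound 4 is expected to land at 600 nM, within 60 nM to 4000 nM, which would mean an estimated at least 1.6-fold lower number from compound 3 to compound 4 (0.22 log units; that floor lies within the scatter).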

Compound 4, half-maximal inhibitory concentration: > 1000 nM
Compound 4 was reported as a limit; the forecaster's own chance of this, stated with the estimate: 35%; middle value at least 1.6-fold (0.22 log units) away from the limit.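

A three-membered ring on this aromatic carbon is therefore not enough on its own: cyclopropylmethyl in place of cyclopropyl brought an at least 120-fold higher number from compound 2 to compound 4 (2.09 log units; beyond the scatter). Of the three groups compared at this place in compounds 2, 3 and 4, only the cyclopropyl of compound 2 gives a number rather than a limit, so the strong inhibition seen in this small set belongs to the ring attached directly to the aromatic carbon and not to the ring as such. Compound 4 is reported only as a limit, as is compound 3, so the step between them cannot be read, and in this assay both stand at the same limit: the limit of > 1000 nM in this assay, at which 2 of the 4 values shown sit.

From the compounds shown here alone, how far compounds 3 and 4 lie beyond that limit stays unknown, and isopropyl and cyclopropylmethyl therefore cannot be ranked against each other. Going by these compounds, whether an ethyl group, a cyclobutyl ring or an amine on this carbon would stay close to compound 2, at 8 nM, remains open.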